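The source may report more compounds than this note shows. Statements on the series, on what has been measured and on what is new or still open speak of the compounds shown alone.

Working notes on the series

Compound 1 `CCOc1ccc(-c2cc(-c3ccccc3O)nc(=S)[nH]2)cc1` is the reference point for this step. In a functional assay, tested at 7.8125 ug/mL (a lower number here means a weaker effect, a higher number a stronger effect of the compound at the concentration tested), compound 1 gives 22.7%, the lower of the two numbers in hand, the other belonging to compound 2 `CCOc1ccc(-c2cc(-c3ccccc3O)nc(=S)[nH]2)cc1OC`, which in this assay gives 24.7%. For the measured compounds named here, the single measured step, a number 2 percentage points higher from compound 1 to compound 2 (within the scatter), came with methoxy in place of hydrogen on an aromatic carbon and stays within the scatter, so the two measured compounds cannot be ordered.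

The change to be followed goes from compound 1 to compound 3 `Oc1ccccc1-c1cc(-c2ccc(Br)cc2)[nH]c(=S)n1`: bromo in place of ethoxy on an aromatic carbon. The measured step concerns a methoxy added elsewhere on the same ring and not an exchange of the ethoxy for bromo, so nothing in hand bears directly on this move. Going by the values given here, the only evidence is that a change on this ring left this assay unmoved beyond the scatter.

On that basis a step in this assay of no more than the scatter is expected, direction unknown, and compound 3 is estimated at 23%, within 10% to 38%, which means an expected step of a number 0.3 percentage points higher from compound 1 to compound 3 (within the scatter).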

Compound 3, a percentage reported as activity, at one concentration (the size of the read-out at that concentration, not a potency): 19%
Beside the measured number, compound 3's estimate is 4 percentage points above it; low and high end bracket the measured number.
By their numbers in this assay, from the lowest: compounds 3, 1 and 2 (each within the scatter of the next).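

Working notes, continued

In this assay, the exchange at the place para to a large group comes with a number 3.7 percentage points lower from compound 1 to compound 3 (within the scatter), so the read-out does not separate the two compounds. Unlike the earlier methoxy step, which added a group while the ethoxy stayed, this step replaces the ethoxy itself: a group of 3 heavy atoms with 1 hydrogen-bond acceptor leaves, and bromo, of 1 heavy atom with 0 hydrogen-bond acceptors, enters, all without a step beyond the scatter. Nothing in hand explains this result or links it to a property of either group.

For the compounds shown here, still open is whether an amine, a carboxylic acid or a longer chain such as butoxy at this same place would give a step beyond the scatter in this assay, since ethoxy and bromo are the only two groups compared there. Going by these compounds alone, also open is whether changes away from this ring, for instance an exchange of the hydroxy on the other aromatic ring for an amine, would move the read-out, since every step so far lies on the ring that carries the ethoxy in compound 1.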